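The source may report more compounds than this note shows. Statements on the series, on what has been measured and on what is new or still open speak of the compounds shown alone.

Measured so far:
compound 1, `Oc1ccccc1-c1cncnc1` — 90000 nM
compound 2, `Oc1ccccc1-c1ncccn1` — > 400000 nM

In an ADME assay on HEK293 cells (Homo sapiens) for cytotoxicity, read by MTT assay, with a stated time of 2 days (a higher number here means a weaker inhibitor, a lower number a stronger inhibitor), compound 1 gives 90000 nM. For compound 2 this assay returns > 400000 nM, which is a limit of the assay and not a number. For the measured compounds named here, compound 1 thus holds the only number in the set; the other entry is the limit of > 400000 nM in this assay, at which 1 of the 2 values shown sits. Going by the values given here, no step between two measured compounds can be drawn from these two entries, so there is no measured change to lean on.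

Compound 3, `c1ccc(-c2cncnc2)cc1`, differs from compound 1 by hydrogen in place of hydroxy on an aromatic carbon. Among the compounds with values here, with no measured step covering this change, the expectation rests on the standing of compound 1 in this assay alone. The step expected in this assay is a 1.7-fold higher number from compound 1 to compound 3 (0.22 log units; within the scatter), small and towards a higher value, and it may well stay within the usual scatter of repeated measurements. Compound 3 is expected to give 150000 nM in this assay, with a range from 50000 nM to 400000 nM. A result reported only as a limit, as for compound 2, is a real possibility for compound 3.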

Compound 3, half-maximal inhibitory concentration: > 400000 nM
Compound 3 ended at the assay's limit (the forecaster's own chance of this, stated with the estimate: 35%); middle value at least 2.6-fold (0.42 log units) from the limit.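

Hydrogen in place of hydroxy on an aromatic carbon, ortho to a group of 6 heavy atoms, gives the first measured step in the series: in this assay the change is an at least 4.4-fold higher number from compound 1 to compound 3 (0.64 log units; beyond the scatter). Substitution at this position is therefore not silent in this assay, and within this pair the hydroxy goes with the lower number, a link that compound 1 and compound 2 alone could not show. For compound 3 the reading of > 400000 nM is a limit of the assay and not a number, so the step has a lower bound but no measured size, and only compound 1 keeps a number in the set: the limit of > 400000 nM in this assay, at which 2 of the 3 values shown sit.

As far as these compounds go, it remains open whether the lower number in compound 1 belongs to the hydroxy specifically or would also appear with another group on the same carbon, such as a methoxy, an amine or a fluorine. The effect of removing the hydroxy from the core of compound 2 also cannot be read from the compounds shown, and a group that brings a reading below the limit would be needed to size any such change.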